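Adding hexyl to the butyl chain of compound 1

This account rests on a few compounds, and the source may have more. Where it says the series, first, only, none or still open, it means among the compounds named here.

In a functional assay on brain (Rattus norvegicus, strain Wistar) for inhibition (on this read-out higher numbers stand for weaker inhibition and lower numbers for stronger inhibition), compound 1 (`CCCCc1ccc(-c2c(C)[nH]c(=O)n2C)cc1`) gives 10700 nM, compound 2 (`CCCCc1ccc(-c2c(CC)[nH]c(=O)n2C)cc1`) gives 13900 nM and compound 3 (`Cc1[nH]c(=O)n(C)c1-c1ccc(C2CCCCC2)cc1`) gives 10000 nM. Compound 1 therefore stands within the scatter of both other compounds. Methyl in place of hydrogen on a saturated chain carbon bound to an aromatic carbon gave a 1.3-fold higher number from compound 1 to compound 2 (0.11 log units; within the scatter). Cyclohexyl in place of butyl on an aromatic carbon gave a 1.1-fold lower number from compound 1 to compound 3 (0.03 log units; within the scatter).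

Compound 4 (`CCCCCCCCCCc1ccc(-c2c(C)[nH]c(=O)n2C)cc1`) carries hexyl in place of hydrogen on a saturated chain carbon, four bonds along the chain from an aromatic carbon. Both measured steps bear on this change only loosely, and neither adds a group of this size at this place. The exchange of the butyl group is the closer guide, and it gave a 1.1-fold lower number from compound 1 to compound 3 (0.03 log units; within the scatter). No step beyond the scatter is therefore expected, though with little certainty. The expected step is a 1.3-fold lower number from compound 1 to compound 4 (0.13 log units; within the scatter). In this assay, compound 4 is estimated at 8000 nM, with an expected range from 2000 nM to 30000 nM.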

Compound 4, half-maximal inhibitory concentration: 7900 nM
Beside the measured number, compound 4's estimate is 1.0-fold (0.01 log units) above it, and the stated range covers the measured number.
By their numbers in this assay, from the lowest: compounds 4, 3, 1 and 2 (each within the scatter of the next).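

In this assay hexyl in place of hydrogen on a saturated chain carbon, four bonds along the chain from an aromatic carbon, gave a 1.4-fold lower number from compound 1 to compound 4 (0.13 log units; within the scatter) and so stayed within the scatter. The earlier steps shown here had exchanged the butyl group for cyclohexyl or added methyl at another place, whereas this step shows that the butyl chain of compound 1 can itself carry a group as large as hexyl with no step beyond the scatter in this read-out. No measurement available here accounts for this result.

As far as these compounds go, whether a longer chain than that of compound 4, an amine or a carboxylic acid at this place would also stay within the scatter remains open. The compounds shown also leave open which change here, if any, would give a step beyond the scatter.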